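Shortening the Amide Side Chains of Compound 1

The source may hold more compounds than are shown below. What is called first, only, known or untested is meant among the compounds shown, and "the series" means these compounds.

Compound 1 `C=CCN(CCCC(=O)O)C(=O)/C(C)=C/c1ccc(C(=O)Oc2ccc(C(=N)N)cc2)cc1` is characterised in an in vitro ADME assay on a cell-free system (plasma) for pharmacokinetics (on this read-out higher numbers stand for a longer-lived compound and lower numbers for a shorter-lived compound), where compound 1 reaches only > 1 h, which is a limit of the assay and not a number. Compound 2 `CCOC(=O)C(C(=O)OCC)N(CCCC(=O)O)C(=O)/C(C)=C/c1ccc(C(=O)Oc2ccc(C(=N)N)cc2)cc1` gives 0.483 h in this assay. Compound 3 `C=CCN(CCCC(=O)OCC)C(=O)/C(C)=C/c1ccc(C(=O)Oc2ccc(C(=N)N)cc2)cc1` sits at < 0.0167 h, again a limit rather than a number. The step of an at least 2.0-fold lower number from compound 1 to compound 2 (0.31 log units; beyond the scatter) was at least modest, while an at least 59-fold lower number from compound 1 to compound 3 (1.77 log units; beyond the scatter) was large. Compound 4 `CCN(CC(=O)O)C(=O)/C(C)=C/c1ccc(C(=O)Oc2ccc(C(=N)N)cc2)cc1` differs from compound 1 by (carboxymethyl)(ethyl)amino in place of allyl(3-carboxypropyl)amino on a carbonyl carbon; like compound 1 it keeps a free carboxylic acid, so the change of substituents on the amide-type nitrogen seen in compound 2 bears more on it than the ester of compound 3. Compound 4 is therefore expected to remain fairly long-lived, with an estimated 1.5 h (range 0.5 h to 5 h), meaning an expected step that the limit leaves unreadable from compound 1 to compound 4 that may lie within scatter or be modestly downward.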

Compound 4, half-life: 1 h
Beside the measured number, compound 4's estimate is 1.5-fold (0.18 log units) above it; the measured number falls inside the stated range.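

With (carboxymethyl)(ethyl)amino in place of allyl(3-carboxypropyl)amino on a carbonyl carbon, and the free carboxylic acid kept, the compound still has a measurable half-life: in this assay compound 4 gives 1 h, which is a number no higher from compound 1 to compound 4 (the limit leaves the size open). The size of this step cannot be read, because compound 1 stands at a limit of the assay: the limit of > 1 h in this assay, at which 1 of the 4 values shown sits.

The compounds shown leave open how each side chain acts alone, since ethyl and carboxymethyl enter together. They also leave open how an ethyl ester or an amine in place of compound 4's carboxylic acid would fare.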